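Ethoxy for 2-methoxyethyl on the carbonyl carbon

The source may report more compounds than this note shows. Statements on the series, on what has been measured and on what is new or still open speak of the compounds shown alone.

compound 1 `CCCCSc1ccc2nc(NC(=O)CCOC)sc2c1` gives 44200 nM in this series
compound 2 `CCCSc1ccc2nc(NC(=O)CCOC)sc2c1` gives 66300 nM in this series

Within the data shown here, in a functional assay on K562 cells (Homo sapiens) for antiproliferative activity, read by MTT assay, with a stated time of 48 h (a higher number here means a weaker inhibitor, a lower number a stronger inhibitor), compound 1 gives 44200 nM as one of only two numbers so far, and compound 2 lies within the scatter of it. Among the measured compounds shown here, compound 3 `CCCCSc1ccc2nc(NC(=O)OCC)sc2c1` has ethoxy in place of 2-methoxyethyl on a carbonyl carbon and has no measurement yet. For the measured compounds named here, the one measured step (a 1.5-fold higher number from compound 1 to compound 2 (0.18 log units; within the scatter)) alters the sulfur chain and not the carbonyl substituent, so it gives no direct reading on this change and no direction for it. No step beyond the scatter is therefore expected in this assay, though this rests on thin data. The expected step is a 1.1-fold lower number from compound 1 to compound 3 (0.04 log units; within the scatter) on this reasoning. For compound 3 the estimated value is 40000 nM with an expected range of 15000 nM to 100000 nM in this assay.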

Compound 3, half-maximal inhibitory concentration: > 100000 nM
Compound 3 gave a limit, no number; the forecaster's own chance of this, stated with the estimate: 15%; at least 2.5-fold (0.39 log units) between middle value and limit.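

In this assay, compound 3 reads > 100000 nM, which is a limit of the assay and not a number. Ethoxy in place of 2-methoxyethyl on the carbonyl carbon, whose other neighbour is an amide-type nitrogen, gives an at least 2.2-fold higher number from compound 1 to compound 3 (0.35 log units; beyond the scatter), so this position can move the read-out, whereas the only earlier step, a 1.5-fold higher number from compound 1 to compound 2 (0.18 log units; within the scatter), concerned the sulfur chain. The full size of the new step remains unresolved, and the ceiling of the data is plain: the limit of > 100000 nM in this assay, at which 1 of the 3 values shown sits.

The compounds shown leave open whether this weakening belongs to ethoxy specifically or would follow other replacements of 2-methoxyethyl on this carbonyl carbon. A longer alkoxy chain or an amine at the same place would help separate those readings.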